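The source may report more compounds than this note shows. Statements on the series, on what has been measured and on what is new or still open speak of the compounds shown alone.

Measured so far in an in vitro functional assay on HEK285-7 cells for antagonist activity at prostaglandin D2 receptor 2 (Homo sapiens), read by BRET and beta-arrestin recruitment; on this read-out lower numbers stand for smaller maximal responses and higher numbers for larger maximal responses:
Compound 1, `O=C(O)Cc1sc(C(c2ccccc2)c2ccc(Cl)cc2)nc1-c1ccc(Cl)cc1`, gives 80%.
Compound 2, `O=C(O)Cc1sc(C(c2ccccc2)c2ccc(Cl)cc2)nc1-c1ccc(F)cc1`, gives 80%.
Compound 3, `O=C(O)Cc1sc(C(c2ccc(F)cc2)c2ccc(F)cc2)nc1-c1cccc(F)c1`, gives 80%.

On these numbers compound 2 stands level with compound 1 and compound 3; all three values lie within the usual scatter of one another, so none of them can be called larger or smaller than the rest. Among the compounds with values here, the one measured step, no change at the digits printed from compound 1 to compound 2 (within the scatter), exchanges fluoro for chloro on an aromatic carbon and leaves the maximal response unchanged within the scatter.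

Compound 4, `O=C(O)Cc1sc(C(c2ccccc2)c2ccc(F)c(F)c2)nc1-c1ccc(F)cc1`, has not yet been measured in this assay. It differs from compound 2 in one place: 3,4-difluorophenyl in place of 4-chlorophenyl on a saturated chain carbon bound to two aromatic carbons. This is again an exchange of one halogen for another on an aromatic ring, here with two fluorines entering where one chlorine leaves. The step from compound 1 to compound 2 is the closest measured guide, and it showed no change beyond the scatter; compound 3, with fluorine on all of its aromatic rings, also gives 80%. Within the data shown here, nothing among the measured compounds points to a shift in either direction.

Compound 4 is therefore expected to give 80%, with a range of 70% to 90%. This estimate means an expected step of no change at the digits printed from compound 2 to compound 4 (within the scatter), which lies within the scatter.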

Compound 4, largest response reached (reported as efficacy), in percent of the reference or control that the assay uses: 80%
Compound 4: middle estimate and measured number agree at the digits printed; low and high end bracket the measured number.
By their numbers in this assay, from the lowest: compounds 1, 2, 3 and 4 (each within the scatter of the next).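

In this assay, putting 3,4-difluorophenyl in place of 4-chlorophenyl on a saturated chain carbon bound to two aromatic carbons gives no change at the digits printed from compound 2 to compound 4 (within the scatter). Within the data shown here, this is the first measured change at this position, and it goes beyond a swap of one halogen for another: one chlorine leaves, two fluorines enter, and the group grows by one heavy atom, yet the maximal response stays within the scatter, as it did in the earlier step at a different place, no change at the digits printed from compound 1 to compound 2 (within the scatter). No measurement shown here offers an explanation for this flat result.

On these data alone, only chlorine and fluorine appear on these aromatic rings, so it remains open whether a methoxy group, a nitrile or an amine on the ring at this position would leave the maximal response level or move it. Every compound also carries the same carboxylic acid on the shared core, which leaves open what an amide in its place would do, and so far no single change has been seen to move this read-out in either direction.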